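Swapping an amide for an imidazole group

This account rests on a few compounds, and the source may have more. Where it says the series, first, only, none or still open, it means among the compounds named here.

compound 1 `CC(=O)c1nc([C@@H](O)[C@H](O)[C@H](O)CO)cn1C` gives 10000 ng.h/mL
compound 2 `CC(=O)N/N=C(\C)c1nc([C@@H](O)[C@H](O)[C@H](O)CO)c[nH]1` gives 1030 ng.h/mL
compound 3 `CN(C)C(=O)c1nc([C@@H](O)[C@H](O)[C@H](O)CO)c[nH]1` gives 1740 ng.h/mL

In an ADME assay on the whole organism (plasma, strain 129/SvEvBrd x C57BL/6) for pharmacokinetics, with Mus musculus as the target, at a dose of 10 mg/kg by the oral route (a higher number here means more compound in the circulation at the dose given, a lower number less compound in the circulation), compound 3 sits within the usual scatter of compound 2, while compound 1 lies higher, beyond that scatter. The next molecule is compound 4 `OC[C@@H](O)[C@@H](O)[C@H](O)c1c[nH]c(-c2ncc[nH]2)n1` with 1H-imidazol-2-yl in place of dimethylcarbamoyl on an aromatic carbon. For the measured compounds named here, no measured pair shows this exact swap, so the guide is indirect. Compound 2 and compound 3 carry different groups at this carbon, yet their numbers stay within the scatter of each other. The estimated change is a 1.2-fold lower number from compound 3 to compound 4 (0.06 log units; within the scatter) and so no step beyond the scatter is expected. Compound 4 is expected at 1500 ng.h/mL (estimated range 400 ng.h/mL to 5500 ng.h/mL).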

Compound 4, area under the concentration-time curve: 1500 ng.h/mL
Compound 4: the middle estimate sits on the measured number at the digits printed; low and high end bracket the measured number.
By their numbers in this assay, from the lowest: compounds 2, 4 and 3 (each within the scatter of the next); then compound 1.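

In this assay, for the compounds shown here, putting 1H-imidazol-2-yl on this aromatic carbon in place of dimethylcarbamoyl gives a 1.2-fold lower number from compound 3 to compound 4 (0.06 log units; within the scatter), the first direct comparison of two groups at this position. The swap brings in a five-membered aromatic ring and a hydrogen-bond donor, yet the two numbers stay within the scatter of each other. Nothing measured here explains this result. Going by these compounds, whether a carboxylic acid or an amine on this carbon would also stay within the scatter remains open. So does the effect of a longer chain there.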